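The source may report more compounds than this note shows. Statements on the series, on what has been measured and on what is new or still open speak of the compounds shown alone.

Working notes on the series. Of the compounds shown here, three with a shared core have been measured: compound 1 `Cc1nc(-c2ccccc2)sc1COc1ccc2c(c1)OCC2CC(=O)O`, compound 2 `Cc1nc(-c2ccc(Cl)cc2)sc1COc1ccc2c(c1)OCC2CC(=O)O` and compound 3 `Cc1ccc(-c2nc(C)c(COc3ccc4c(c3)OCC4CC(=O)O)s2)cc1`. In an assay on CHO cells for agonist activity at Free fatty acid receptor 1 (Homo sapiens), read by FLIPR (on this read-out higher numbers stand for an effect only at larger amounts of compound and lower numbers for an effect already at smaller amounts), compound 1 gives 102 nM, compound 2 gives 105 nM and compound 3 gives 94 nM. The steps between them are all small: a 1.0-fold higher number from compound 1 to compound 2 (0.01 log units; within the scatter), a 1.1-fold lower number from compound 1 to compound 3 (0.04 log units; within the scatter) and a 1.1-fold lower number from compound 2 to compound 3 (0.05 log units; within the scatter). Compound 3 therefore cannot be told apart from compound 1 or compound 2 in this assay; the three numbers sit together within the scatter.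

Next in line is compound 4 `Cc1nc(-c2ccc(C(F)(F)F)cc2)sc1COc1ccc2c(c1)OCC2CC(=O)O`. It differs from compound 3 by trifluoromethyl in place of methyl on an aromatic carbon, the place being an aromatic carbon of a six-membered aromatic ring of carbon only, para to a large group. For the measured compounds named here, the steps that bear on this are the exchanges at that same place: from compound 1 to compound 2 and from compound 2 to compound 3, both within the scatter, as is the step from compound 1 to compound 3. Hydrogen, chloro and methyl at that place give the same number, so a trifluoromethyl there is expected to leave this assay unchanged beyond the scatter: the estimated step is a 1.1-fold higher number from compound 3 to compound 4 (0.03 log units; within the scatter). Compound 4 is accordingly expected to give 100 nM, with a range from 50 nM to 210 nM.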

Compound 4, half-maximal effective concentration: 113 nM
The estimate for compound 4 lay 1.1-fold (0.05 log units) below the measured number; low and high end bracket the measured number.
By their numbers in this assay, from the lowest: compounds 3, 1, 2 and 4 (each within the scatter of the next).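

Trifluoromethyl now joins hydrogen, chloro and methyl at this place. In this assay the change gives a 1.2-fold higher number from compound 3 to compound 4 (0.08 log units; within the scatter), and the exchanges for the other two groups give a 1.1-fold higher number from compound 2 to compound 4 (0.03 log units; within the scatter) and a 1.1-fold higher number from compound 1 to compound 4 (0.04 log units; within the scatter). On an aromatic carbon of a six-membered aromatic ring of carbon only, para to a large group, the series therefore tolerates the group with the most heavy atoms so far, and the first one carrying fluorine, with no step beyond the scatter among these four compounds. Nothing on hand bears on why the number stays flat across these groups.

It remains open whether an amine, a carboxylic acid or a longer alkyl chain at this same place would also stay within the scatter of these compounds in this assay. The four compounds also differ only at this place, so they give no reading on how the same exchanges would behave elsewhere on the shared core.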